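Cytotoxicity notes on the aryl sulfonamide thiazole series

A few compounds are considered here, and "the series" means these few. Any claim that something is new, unique, unknown or untested is made for them only; others in the source may bear on it.

Measured so far in an ADME assay on HepG2 2.2.15 cells (Homo sapiens) for cytotoxicity; a lower number here means that less compound is tolerated, a higher number that more compound is tolerated:
- compound 1 `O=S(=O)(Nc1ncc(C(Oc2ccc3cc(Br)ccc3c2)c2ccc(Cl)cc2)s1)c1cccs1`: "not toxic" (no number reported)
- compound 2 `Cc1ccc(C)c(S(=O)(=O)Nc2ncc(C(Oc3ccc4cc(Br)ccc4c3)c3ccc(Cl)cc3)s2)c1`: > 50000 nM
- compound 3 `O=S(=O)(Nc1ncc(C(Oc2ccc3cc(Br)ccc3c2)c2ccc(Cl)cc2)s1)c1ccc(Cl)nc1`: "not toxic" (no number reported)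

Compound 3 has no single number in this assay; its entry reads "not toxic" (no number reported). Compound 1 likewise carries a word-only entry in this assay, "not toxic" (no number reported). For compound 2 the entry in this assay is a limit of the assay, > 50000 nM. Among the three compounds there is thus no numeric point to rank compound 3 against, only the limit of > 50000 nM in this assay, at which 1 of the 3 values shown sits, and two entries without a number. Within the data shown here, no step between two measured compounds that differ in one place exists in this set.

Compound 4 `Cc1ccc(S(=O)(=O)Nc2ncc(C(Oc3ccc4cc(Br)ccc4c3)c3ccc(Cl)cc3)s2)c2ccccc12` is the next member to be tested in this assay. It differs from compound 3 by 4-methylnaphthalen-1-yl in place of 6-chloropyridin-3-yl on a sulfonyl sulfur. Compared with compound 3, no change beyond the usual scatter is expected in this assay, the most likely outcome being another limit rather than a number. For compound 4 the expected half-maximal cytotoxic concentration in this assay is 50000 nM, with a range from 20000 nM to 100000 nM.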

Compound 4, half-maximal cytotoxic concentration: > 50000 nM
Compound 4 ended at the assay's limit; the forecaster's own chance of this, stated with the estimate: 70%; the middle value sits exactly at the limit.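

In this assay compound 4 gives > 50000 nM as a limit of the assay, not a number. Among these compounds, compound 2 likewise gives > 50000 nM as a limit, so no step between compound 2 and compound 4 can be read. The compounds shown leave open where the half-maximal cytotoxic concentration of any of them lies, and whether the group on the sulfonyl sulfur changes it.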